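Benzoxazole to Benzothiazole Swap in Two Oxadiazole Thioethers

The compounds below may be only part of what the source reports. "The series", "measured", "known", "first", "only" and "open" are said of these compounds alone.

Measured compounds:
- compound 1, `c1ccc(-c2nnc(SCCCN3CCN(c4nc5ccccc5o4)CC3)o2)cc1`: 67000 nM
- compound 2, `O=C(NCc1nnc(SCCCN2CCN(c3nc4ccccc4o3)CC2)o1)c1ccccc1`: 63900 nM
- compound 3, `c1ccc(-c2nnc(SCCCN3CCN(c4nc5ccccc5s4)CC3)o2)cc1`: 229000 nM

All three were tested in a functional assay on HeLa cells (Homo sapiens) for inhibition, read by MTT assay, with a stated time of 72 h; on this read-out lower numbers stand for stronger inhibition and higher numbers for weaker inhibition. Compound 1 and compound 2 share the same core and differ only at one aromatic carbon of the five-membered ring: benzamidomethyl in place of phenyl on an aromatic carbon. This change made a 1.0-fold lower number from compound 1 to compound 2 (0.02 log units; within the scatter), so the two numbers cannot be told apart.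

Compound 3 carries a different core than compound 1; the difference is 1,3-benzothiazol-2-yl in place of 1,3-benzoxazol-2-yl on an amine nitrogen in a ring. That change made a 3.4-fold higher number from compound 1 to compound 3 (0.53 log units; beyond the scatter). Among the three measured compounds, compound 3 gives the highest number, and its steps to the other two are beyond the scatter.

Compound 4, `O=C(NCc1nnc(SCCCN2CCN(c3nc4ccccc4s3)CC2)o1)c1ccccc1`, has not yet been measured in this assay. It relates to compound 3 exactly as compound 2 relates to compound 1: benzamidomethyl in place of phenyl on an aromatic carbon. The place of the change reads the same in both pairs, so this is the same change, made on the core of compound 3 rather than the core of compound 1. Since that change made a 1.0-fold lower number from compound 1 to compound 2 (0.02 log units; within the scatter), the expected step here is also small: the estimate for the step from compound 3 to compound 4 is a 1.0-fold lower number from compound 3 to compound 4 (0.02 log units; within the scatter). Among the compounds with values here, compound 4 is therefore expected to give about 220000 nM in this assay, with an expected range from 90000 nM to 520000 nM, resting on the single earlier instance of this change and on the value of compound 3, 229000 nM.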

Compound 4, half-maximal inhibitory concentration: 78100 nM
Compound 4: the middle estimate sits 2.8-fold (0.45 log units) above what was measured; the whole stated range lies above it.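

In this assay, benzamidomethyl in place of phenyl did not behave the same way on both cores: on the core of compound 3 it gave a 2.9-fold lower number from compound 3 to compound 4 (0.47 log units; beyond the scatter), and this differs from its earlier instance: the same change on two cores in this assay, a 1.0-fold lower number (0.02 log units; within the scatter) from compound 1 to compound 2 and a 2.9-fold lower number (0.47 log units; beyond the scatter) from compound 3 to compound 4, 2.8-fold (0.45 log units) apart, beyond the scatter of two such steps. Read from the other side, 1,3-benzothiazol-2-yl in place of 1,3-benzoxazol-2-yl gave a 1.2-fold higher number from compound 2 to compound 4 (0.09 log units; within the scatter), and this too differs from its earlier instance: the same change on two cores in this assay, a 3.4-fold higher number (0.53 log units; beyond the scatter) from compound 1 to compound 3 and a 1.2-fold higher number (0.09 log units; within the scatter) from compound 2 to compound 4, 2.8-fold (0.45 log units) apart, beyond the scatter of two such steps. So in these four compounds, the size of each step depends on what sits at the other place, and a step measured on one core cannot simply be carried to the other; however, the two comparisons are one gap seen from two sides, so this is a single example, and it does not show why the steps differ or whether the same would happen with other groups.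

The compounds shown leave open whether this dependence would recur with a different group on that aromatic carbon, such as an aminomethyl group or a carboxylic acid. They also leave open what a shorter or longer thioether chain would do to either step.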